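The compounds below may be only part of what the source reports. "The series", "measured", "known", "first", "only" and "open" are said of these compounds alone.

Within an assay on microsomes from liver for inhibition of 3-hydroxy-3-methylglutaryl-coenzyme A reductase (Rattus norvegicus) (a lower number here means a stronger inhibitor, a higher number a weaker inhibitor), compound 3 `COCc1cccc(CNC(=O)c2nn(-c3ccc(F)cc3)c(OC[C@@H](O)C[C@@H](O)CC(=O)O)c2C(C)C)c1` sits highest of the three measured numbers, at 31 nM. Compound 1 `CC(C)c1c(C(=O)N2CCC[C@H](c3ccccc3)C2)nn(-c2ccc(F)cc2)c1OC[C@@H](O)C[C@@H](O)CC(=O)O` gives 4.8 nM and compound 2 `COc1ccc(CNC(=O)c2nn(-c3ccc(F)cc3)c(OC[C@@H](O)C[C@@H](O)CC(=O)O)c2C(C)C)cc1` gives 12 nM; the steps run a 2.5-fold higher number from compound 1 to compound 2 (0.40 log units; beyond the scatter), a 6.5-fold higher number from compound 1 to compound 3 (0.81 log units; beyond the scatter) and a 2.6-fold higher number from compound 2 to compound 3 (0.41 log units; beyond the scatter). Compound 4 `CC(C)c1c(C(=O)NCc2ccccc2Cl)nn(-c2ccc(F)cc2)c1OC[C@@H](O)C[C@@H](O)CC(=O)O` is not yet measured; its change from compound 3 is 2-chlorophenyl in place of 3-(methoxymethyl)phenyl on a saturated chain carbon bound to an amide-type nitrogen. Among the compounds with values here, the one measured step on the same saturated chain carbon, a 2.6-fold higher number from compound 2 to compound 3 (0.41 log units; beyond the scatter), was modest, and the two changes at the amide-type nitrogen were modest as well, so variation in this part of the series has moved this assay only by small amounts. A modest downward step is therefore expected, a 1.7-fold lower number from compound 3 to compound 4 (0.24 log units; within the scatter), with a chance that it stays within the scatter. The estimate for compound 4 in this assay is 18 nM, with a range of 7 nM to 50 nM.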

Compound 4, half-maximal inhibitory concentration: 9.5 nM
Compound 4: middle estimate off by 1.9-fold (0.28 log units), on the high side; the range from low to high includes it.
By their numbers in this assay, from the lowest: compounds 1, 4 and 2 (each within the scatter of the next, the first and the last beyond it); then compound 3.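

Swapping 3-(methoxymethyl)phenyl for 2-chlorophenyl on the saturated chain carbon bound to an amide-type nitrogen lowers the number in this assay (a 3.3-fold lower number from compound 3 to compound 4 (0.51 log units; beyond the scatter)), the first downward step at this position. Set against 4-methoxyphenyl, 2-chlorophenyl gives no separation (a 1.3-fold lower number from compound 2 to compound 4 (0.10 log units; within the scatter)), leaving 3-(methoxymethyl)phenyl alone at the weak end. Unlike the two methoxy-bearing benzyl amides, (2-chlorobenzyl)amino stays within the scatter of 3-phenylpiperidin-1-yl (a 2.0-fold higher number from compound 1 to compound 4 (0.30 log units; within the scatter)). On these data alone, how an unsubstituted benzyl, a 2-fluorobenzyl or a benzyl carrying a carboxylic acid would compare remains open. Nothing available explains these differences.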